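Replacing an oxazolyl amine with an anilino group on a shared core

This account rests on a few compounds, and the source may have more. Where it says the series, first, only, none or still open, it means among the compounds named here.

Measured compounds:
compound 1 `O=C(Nc1ccccc1)c1cnc(NCc2c(F)ccc3c2CCO3)n2cnnc12`: 4.1
compound 2 `CN(c1ccccc1)c1cnc(NCc2c(F)ccc3c2CCO3)n2cnnc12`: 3.6
compound 3 `CN(c1ncco1)c1cnc(NCc2c(F)ccc3c2CCO3)n2cnnc12`: 2.1

In a physicochemical assay for lipophilicity, using the shake flask method, in phosphate buffer, measured as octanol-water partition, with a stated time of 30 min, at pH 7.4 (on this read-out higher numbers stand for higher lipophilicity and lower numbers for lower lipophilicity), compound 3 gives the lowest of the three numbers, with compound 2 nearest and compound 1 furthest. Compound 4 `Fc1ccc2c(c1CNc1ncc(Nc3ccccc3)c3nncn13)CCO2` differs from compound 3 in one place: anilino in place of methyl(1,3-oxazol-2-yl)amino on an aromatic carbon. The step of a number 1.50 log units lower from compound 2 to compound 3 (beyond the scatter) bears directly on this change, since it exchanges the same phenyl and 1,3-oxazol-2-yl groups on the same nitrogen; the step of a number 0.50 log units lower from compound 1 to compound 2 (beyond the scatter) bears less, as it alters the linker rather than the ring. Compound 4 resembles compound 2, lacking only the methyl on the nitrogen, so a large rise is expected: a number 1.20 log units higher from compound 3 to compound 4 (beyond the scatter). Compound 4 is therefore estimated at 3.3, between 2.8 and 3.8.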

Compound 4, distribution coefficient: 3.3
Compound 4: the middle estimate sits on the measured number at the digits printed; the measured number falls inside the stated range.
By their numbers in this assay, from the lowest: compound 3; then compounds 4 and 2 (each within the scatter of the next); then compound 1.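

With hydrogen in place of methyl on the nitrogen at this position, this assay shows no difference beyond the scatter: a number 0.30 log units lower from compound 2 to compound 4 (within the scatter). Anilino in place of methyl(1,3-oxazol-2-yl)amino gives a number 1.20 log units higher from compound 3 to compound 4 (beyond the scatter), so with the methyl step inside the scatter, this large gap tracks the ring on that nitrogen. The direct exchange of phenylcarbamoyl for anilino gives a number 0.80 log units lower from compound 1 to compound 4 (beyond the scatter). No measurement shown here explains these differences. On these data alone, how a 1,3-oxazol-2-ylamino group without the methyl, or a benzylamino group, would read at this position remains open.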